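Swapping bromo for hydroxy on the aryl urea of compound 2

The source may hold more compounds than are shown below. What is called first, only, known or untested is meant among the compounds shown, and "the series" means these compounds.

Measured compounds:
Compound 1: `COc1cc(NC(C)CCCNC(=O)NNC(=O)Nc2cc(C(F)(F)F)cc(C(F)(F)F)c2)c2ncccc2c1` gives 20000 nM in a functional assay on MIA PaCa-2 cells (Homo sapiens) for inhibition, read by MTT assay, with a stated time of 72 h; a higher number here means a weaker inhibitor, a lower number a stronger inhibitor.
Compound 2: `COc1cc(NC(C)CCCNC(=O)NNC(=O)Nc2ccc(Br)cc2)c2ncccc2c1` gives 231000 nM in this assay.
Compound 3: `COc1cc(NC(C)CCCNC(=O)NNC(=O)Nc2cccc(C(F)(F)F)c2)c2ncccc2c1` gives 5600 nM in this assay.

Compound 2 stands highest of the three numbers in this assay; compound 1 sits nearest to it, and compound 3 furthest from it. The unmeasured compound 4, `COc1cc(NC(C)CCCNC(=O)NNC(=O)Nc2ccc(O)cc2)c2ncccc2c1`, differs from compound 2 by hydroxy in place of bromo on an aromatic carbon.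

For the measured compounds named here, two measured steps bear on this. The step of a 41-fold lower number from compound 2 to compound 3 (1.62 log units; beyond the scatter) shows that changing the aryl group on the amide-type nitrogen of compound 2 can move the number a great deal, and the step of a 3.6-fold lower number from compound 1 to compound 3 (0.55 log units; beyond the scatter) shows that even removing one trifluoromethyl shifts it. Going by the values given here, neither step, however, involves a hydroxy group, so no direct precedent exists for the change in compound 4. The expectation is therefore uncertain: a step in this assay of some size is plausible in either direction, and compound 4 is expected to give 150000 nM, within the range 30000 nM to 600000 nM. The expected step from compound 2 is a 1.5-fold lower number from compound 2 to compound 4 (0.19 log units; within the scatter).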

Compound 4, half-maximal inhibitory concentration: 142000 nM
For compound 4 the middle estimate is 1.1-fold (0.02 log units) above the measured one; measured number inside the range.
By their numbers in this assay, from the lowest: compound 3; then compound 1; then compounds 4 and 2 (each within the scatter of the next).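

In this assay, the step of a 1.6-fold lower number from compound 2 to compound 4 (0.21 log units; within the scatter) shows that bromo and hydroxy cannot be told apart at this position, para to a large group, even though hydroxy brings a hydrogen-bond donor and acceptor that bromo lacks. The aryl group had already proved able to move the number, and the step of a 25-fold higher number from compound 3 to compound 4 (1.40 log units; beyond the scatter) shows that 4-hydroxyphenyl, like 4-bromophenyl, stands well apart from the 3-(trifluoromethyl)phenyl of compound 3. Nothing available explains why bromo and hydroxy read alike here.

The compounds shown leave open whether an amine or a carboxylic acid at this same position would also read like bromo and hydroxy. They also leave open what hydroxy would do in the place trifluoromethyl holds in compound 3.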